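From benzyl to phenylsulfonyl on the imidazole nitrogen

The compounds below may be only part of what the source reports. "The series", "measured", "known", "first", "only" and "open" are said of these compounds alone.

Three compounds share one core and differ only in the group on an aromatic nitrogen of the five-membered ring. In an assay on isolated protein with dual specificity calcium/calmodulin-dependent 3',5'-cyclic nucleotide phosphodiesterase 1B (Bos taurus) as the target, tested at 100 uM (on this read-out lower numbers stand for less inhibition and higher numbers for more inhibition at the one concentration tested (going by the name of the read-out)), compound 1 `CC(C)Cn1c(N)nc2c1c(=O)n(CC1CC1)c(=O)n2CC1CC1` gives 12%, compound 2 `Nc1nc2c(c(=O)n(CC3CC3)c(=O)n2CC2CC2)n1Cc1ccccc1` gives 27%, and compound 3 `Nc1nc2c(c(=O)n(CC3CC3)c(=O)n2CC2CC2)n1Cc1cccc2ccccc12` gives 0%. Compound 2 stands highest of the three, with compound 1 nearest and compound 3 furthest below it. The measured steps are all modest: a number 15 percentage points higher from compound 1 to compound 2 (beyond the scatter), a number 27 percentage points lower from compound 2 to compound 3 (beyond the scatter) and a number 12 percentage points lower from compound 1 to compound 3 (beyond the scatter).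

Compound 4 `Nc1nc2c(c(=O)n(CC3CC3)c(=O)n2CC2CC2)n1S(=O)(=O)c1ccccc1` differs from compound 2 in one place: phenylsulfonyl in place of benzyl on an aromatic nitrogen. Among the compounds with values here, no measured step involves a phenylsulfonyl group, so the earlier steps bear only indirectly; they show that exchanging the group on this nitrogen moves this assay by modest amounts in either direction, as the gain from compound 1 to compound 2 and the loss from compound 2 to compound 3 illustrate. The aromatic ring is kept, but the saturated carbon that linked it gives way to a sulfonyl, and the data give no guide for that. He therefore expects a modest downward step, a number 12 percentage points lower from compound 2 to compound 4 (beyond the scatter), with wide uncertainty. Compound 4 is estimated to give 15% in this assay, within a range from 0% to 40%.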

Compound 4, a percentage reported as inhibition, at one concentration (the size of the read-out at that concentration, not a potency): 13%
Beside the measured number, compound 4's estimate is 2 percentage points above it, and the stated range covers the measured number.
By their numbers in this assay, from the lowest: compound 3; then compounds 1 and 4 (each within the scatter of the next); then compound 2.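

In this assay, the change to a sulfonyl link shows that keeping the aromatic ring on this aromatic nitrogen does not keep the number of the benzyl compound: replacing benzyl with phenylsulfonyl gives a number 14 percentage points lower from compound 2 to compound 4 (beyond the scatter) and so costs about as much as the earlier step away from benzyl to isobutyl would in reverse. Set against the isobutyl group, phenylsulfonyl cannot be told apart, with a number 1 percentage points higher from compound 1 to compound 4 (within the scatter) on that exchange, so a group with an aromatic ring and a sulfonyl and a saturated branched chain land at the same level in these data, and among the groups shown only benzyl stands clear of the rest. Nothing in the data at hand explains why this exchange lowers the number.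

The compounds shown leave open whether the step goes with the sulfonyl itself or with the loss of the saturated carbon, a question that a benzoyl group or a phenethyl group on this aromatic nitrogen would bear on. Also open, on these data alone, is how a methoxy group or a carboxylic acid on the phenyl ring of either the benzyl or the phenylsulfonyl group would move the number in this assay on the shared core.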